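The source may report more compounds than this note shows. Statements on the series, on what has been measured and on what is new or still open speak of the compounds shown alone.

Measured compounds:
- compound 1 `C=C1C(=O)O[C@H]2CC3=C[C@H](C/C(C)=C/[C@@H](OC(=O)/C=C/c4ccc(N(C)C)cc4)[C@H]12)OC3=O`: 1300 nM
- compound 2 `C=C1C(=O)O[C@H]2CC3=C[C@H](C/C(C)=C/[C@@H](OC(=O)C4CCC(F)(F)CC4)[C@H]12)OC3=O`: limit, > 10000 nM
- compound 3 `C=C1C(=O)O[C@H]2CC3=C[C@H](C/C(C)=C/[C@@H](OC(=O)C(C)(C)CC)[C@H]12)OC3=O`: 6100 nM

All three share one core and differ only in the ester group attached to it. In a functional assay on NCI-H460 cells (Homo sapiens) for cytotoxicity, read by MTT assay, with a stated time of 48 h (a higher number here means a weaker inhibitor, a lower number a stronger inhibitor), compound 1 gives 1300 nM, the lowest number among the compounds with a measured value. Compound 2 reaches only a limit of the assay, > 10000 nM. Compound 3 gives 6100 nM. Replacing the 2-(4-(dimethylamino)phenyl)ethenyl group on the carbonyl carbon has so far only raised the number: an at least 7.6-fold higher number from compound 1 to compound 2 (0.88 log units; beyond the scatter) and a 4.7-fold higher number from compound 1 to compound 3 (0.67 log units; beyond the scatter).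

Compound 4 `C=C1C(=O)O[C@H]2CC3=C[C@H](C/C(C)=C/[C@@H](OC(=O)c4ccncc4)[C@H]12)OC3=O` is not yet measured. Its change from compound 1 is pyridin-4-yl in place of 2-(4-(dimethylamino)phenyl)ethenyl on a carbonyl carbon. Unlike compounds 2 and 3, compound 4 keeps an aromatic ring on the carbonyl carbon, so the step is expected to be smaller than those two, but still upward: a step of a 2.7-fold higher number from compound 1 to compound 4 (0.43 log units; beyond the scatter) is estimated. Compound 4 is therefore expected to give about 3500 nM in this assay, within a range of 1500 nM to 10000 nM.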

Compound 4, half-maximal inhibitory concentration: 5600 nM
Compound 4: middle estimate off by 1.6-fold (0.20 log units), on the low side, and the stated range covers the measured number.
By their numbers in this assay, from the lowest: compound 1; then compounds 4 and 3 (each within the scatter of the next). At a limit, above all of these: compound 2.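

Keeping an aromatic ring on the carbonyl carbon does not by itself preserve the number of compound 1 in this assay, since pyridin-4-yl gives a 4.3-fold higher number from compound 1 to compound 4 (0.63 log units; beyond the scatter) in that assay. Aromatic pyridin-4-yl and non-aromatic 1,1-dimethylpropyl also cannot be told apart: the step is a 1.1-fold lower number from compound 3 to compound 4 (0.04 log units; within the scatter). Compound 2 stands at a limit: the limit of > 10000 nM in this assay, at which 1 of the 4 values shown sits. That leaves only a floor for its step, an at least 1.7-fold lower number from compound 2 to compound 4 (0.25 log units; that floor lies within the scatter).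

On these data alone, what remains open is which part of the 2-(4-(dimethylamino)phenyl)ethenyl group goes with the lower number of compound 1: the ethenyl link, the dimethylamino group or the benzene ring. A plain 2-phenylethenyl group, or a 4-(dimethylamino)phenyl group set directly on the carbonyl carbon, would separate these parts.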